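Working notes: aryl exchange from compound 2 to compound 4

The compounds below may be only part of what the source reports. "The series", "measured", "known", "first", "only" and "open" are said of these compounds alone.

Measured so far in a functional assay on HepG2 cells (Homo sapiens) for cytotoxicity, read by MTT assay, with a stated time of 72 h (a higher number here means a weaker inhibitor, a lower number a stronger inhibitor), as follows
- compound 1 `O=C(N/N=C/c1cccc(Cl)c1Cl)Nc1cc2c(Nc3ccc(F)c(Cl)c3)ncnc2cc1O[C@H]1CCOC1` gives 16900 nM
- compound 2 `COc1ccc(/C=N/NC(=O)Nc2cc3c(Nc4ccc(F)c(Cl)c4)ncnc3cc2O[C@H]2CCOC2)c(OC)c1OC` gives 29300 nM
- compound 3 `CC(C)(C)c1cc(/C=N/NC(=O)Nc2cc3c(Nc4ccc(F)c(Cl)c4)ncnc3cc2O[C@H]2CCOC2)cc(C(C)(C)C)c1O` gives 12500 nM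

Compound 2 at 29300 nM stands at the upper end of these three values, while compound 3 at 12500 nM lies lower. Next comes compound 4 `CCN(CC)c1ccc(/C=N/NC(=O)Nc2cc3c(Nc4ccc(F)c(Cl)c4)ncnc3cc2O[C@H]2CCOC2)c(O)c1` with 4-(diethylamino)-2-hydroxyphenyl in place of 2,3,4-trimethoxyphenyl on a carbon with a double bond to nitrogen as its structural change. For the measured compounds named here, since a 1.7-fold higher number from compound 1 to compound 2 (0.24 log units; within the scatter) is the only measured step at that carbon, no shift beyond the scatter is expected in this assay for this exchange. The estimated move is a 1.8-fold lower number from compound 2 to compound 4 (0.26 log units; within the scatter) and would be a small one. For compound 4 the estimate is 16000 nM with an expected range from 6000 nM to 32000 nM as a working figure.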

Compound 4, half-maximal inhibitory concentration: 15700 nM
Beside the measured number, compound 4's estimate is 1.0-fold (0.01 log units) above it; the measured number falls inside the stated range.
By their numbers in this assay, from the lowest: compounds 3, 4, 1 and 2 (each within the scatter of the next, the first and the last beyond it).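

At the carbon with a double bond to nitrogen, 4-(diethylamino)-2-hydroxyphenyl in place of 2,3,4-trimethoxyphenyl gives a 1.9-fold lower number from compound 2 to compound 4 (0.27 log units; within the scatter), and in place of 2,3-dichlorophenyl gives a 1.1-fold lower number from compound 1 to compound 4 (0.03 log units; within the scatter). An aryl group carrying a hydrogen-bond donor and a diethylamino group thus joins compounds 1 and 2 within the scatter of each other, so this exchange separates none of the three. No measurement shown bears on the reason for this result. Open, from the compounds shown here alone, is whether a carboxylic acid on the phenyl ring, or a saturated ring such as cyclohexyl in its place, would give a step beyond the scatter.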